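Tert-butyl to cyclopentyl ester: working notes

A few compounds are considered here, and "the series" means these few. Any claim that something is new, unique, unknown or untested is made for them only; others in the source may bear on it.

Measured in a functional assay on K562 cells (Homo sapiens) for inhibition; a lower number here means a stronger inhibitor, a higher number a weaker inhibitor:
- compound 1 `CC1(C)OC2OC(C(O)CO)C(OC(=O)CC(c3ccccc3)c3ccccc3)C2O1`: 500000 nM
- compound 2 `CC1(C)OC2OC(C(O)CO)C(OC(=O)C(C)(C)C)C2O1`: 1500000 nM

Compound 2, at 1500000 nM, holds the higher of the two numbers, which makes it the weaker inhibitor of the pair. The gap to compound 1 lies beyond the usual scatter.

The next compound to be tested is compound 3 `CC1(C)OC2OC(C(O)CO)C(OC(=O)C3CCCC3)C2O1`, which has cyclopentyl in place of tert-butyl on a carbonyl carbon. Going by the values given here, no measured pair isolates a change at this carbonyl carbon, so the data offer only weak guidance. Among the compounds with values here, the one available reference is compound 1 at 500000 nM, which sits lower than compound 2.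

A modest move toward a lower number is therefore expected in this assay, and the estimated 1.5-fold lower number from compound 2 to compound 3 (0.18 log units; within the scatter) may stay within the scatter. For compound 3 the estimated value is 1000000 nM, with an expected range of 450000 nM to 2200000 nM.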

Compound 3, half-maximal inhibitory concentration: 2500000 nM
Estimate against measurement, compound 3: 2.5-fold (0.40 log units) below, and the stated range ends below it.
By their numbers in this assay, from the lowest: compound 1; then compounds 2 and 3 (each within the scatter of the next).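

In this assay, going by these compounds alone, replacing tert-butyl with cyclopentyl on a carbonyl carbon gives a 1.7-fold higher number from compound 2 to compound 3 (0.22 log units; within the scatter), and this is the first pair to isolate a change at this position. At this position, tert-butyl and cyclopentyl cannot be told apart in this assay, so introducing the five-membered ring of carbon only gives no measurable separation between compound 2 and compound 3. No supporting data are available to account for this result.

The compounds shown leave open whether an amine or a carboxylic acid on the acyl group would shift the number beyond the scatter in this assay. On these data alone, it also remains open how a longer chain or a cyclohexyl group at this carbonyl carbon would compare with tert-butyl.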